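This account rests on a few compounds, and the source may have more. Where it says the series, first, only, none or still open, it means among the compounds named here.

- Compound 1 `CNC(=O)CCSc1ccc2c(/C=C/c3ccccn3)n[nH]c2c1`: > 10000 nM (a limit of the assay, not a number)
- Compound 2 `COc1cccc(NC(=O)CCSc2ccc3c(/C=C/c4ccccn4)n[nH]c3c2)c1`: 3840 nM
- Compound 3 `O=C(CCSc1ccc2c(/C=C/c3ccccn3)n[nH]c2c1)Nc1cccc(C(F)(F)F)c1`: 2300 nM

In an ADME assay on BaF3 cells (Mus musculus) for antiproliferative activity, read by CCK-8 assay, with a stated time of 72 h (on this read-out higher numbers stand for weaker inhibition of growth and lower numbers for stronger inhibition of growth), compound 3 gives 2300 nM. It shares its place with compound 2, since the step of a 1.7-fold lower number from compound 2 to compound 3 (0.22 log units; within the scatter) lies within the scatter. Both stand apart from the methyl amide. Putting 3-methoxyphenyl in place of methyl gives the step of an at least 2.6-fold lower number from compound 1 to compound 2 (0.41 log units; beyond the scatter), and putting 3-(trifluoromethyl)phenyl in place of methyl gives the step of an at least 4.3-fold lower number from compound 1 to compound 3 (0.63 log units; beyond the scatter). Both lie beyond the scatter.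

Compound 4 `Cc1ccc(NC(=O)CCSc2ccc3c(/C=C/c4ccccn4)n[nH]c3c2)cc1` has 4-methylphenyl in place of 3-(trifluoromethyl)phenyl on an amide-type nitrogen. The six-membered aromatic ring of carbon stays, and only the group on it changes. The nearest measured guide is therefore the exchange of trifluoromethyl and methoxy, where the step of a 1.7-fold lower number from compound 2 to compound 3 (0.22 log units; within the scatter) stayed within the scatter. Going by the values given here, no measured compound carries 4-methylphenyl, so this guide is only indirect, and a wide range is sensible. No change beyond the scatter is expected, and the estimated step is a 1.3-fold higher number from compound 3 to compound 4 (0.12 log units; within the scatter). For compound 4 the expected value is 3000 nM, with an estimated range of 1300 nM to 7500 nM.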

Compound 4, concentration for 50% growth inhibition: > 10000 nM
Compound 4: only a limit was reported (the forecaster's own chance of this, stated with the estimate: 10%); middle value at least 3.3-fold (0.52 log units) from the limit.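

In this assay, compound 4 reports only a limit, > 10000 nM, not a number. The exchange of 3-(trifluoromethyl)phenyl or 3-methoxyphenyl for 4-methylphenyl on the amide-type nitrogen therefore gives an at least 4.3-fold higher number from compound 3 to compound 4 (0.63 log units; beyond the scatter) and an at least 2.6-fold higher number from compound 2 to compound 4 (0.41 log units; beyond the scatter), both larger than the earlier comparison between compound 2 and compound 3 would have suggested. Compounds 1 to 3 could be read as saying that a six-membered aromatic ring of carbon in place of methyl is enough to improve growth inhibition, but compound 4 carries such a ring and goes against that reading, so what counts here is the group on the ring or where it sits. The step between compound 1 and compound 4 cannot be read, because both rest on the same limit: the limit of > 10000 nM in this assay, at which 2 of the 4 values shown sit.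

Compound 4 differs from compound 2 and compound 3 both in the group on the ring and in its place, so these results cannot separate the two. A 3-methylphenyl or a 4-(trifluoromethyl)phenyl group on the same nitrogen would tell them apart, and an unsubstituted phenyl group would show what the ring does on its own.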